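The source may report more compounds than this note shows. Statements on the series, on what has been measured and on what is new or still open speak of the compounds shown alone.

Working notes on the hydroxyurea series. Two compounds have been run in a physicochemical assay for lipophilicity, measured as octanol-water partition, with a stated time of 72 h; on this read-out lower numbers stand for lower lipophilicity and higher numbers for higher lipophilicity. Compound 1, `CC(C)NC(=O)NO`, gives 0.2 in this assay. Compound 2, `O=C(NO)Nc1ccccc1`, gives 0.41 in this assay. Within the data shown here, of the two numbers so far, compound 1 stands at the value from which compound 2 departs by an amount within the usual scatter, so the two are not told apart on this read-out.

The next compound, compound 3, `CCNC(=O)NO`, has not yet been run in this assay. It differs from compound 1 in one place: hydrogen in place of methyl on a saturated chain carbon bound to an amide-type nitrogen and a saturated chain carbon. Among the measured compounds shown here, no measured pair in the set shows a step of this kind, so nothing fixes its size. On general grounds, loss of a methyl from a saturated chain tends to lower partition, and the size of such a step usually lies around the scatter of this assay, perhaps a little beyond it.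

For compound 3 in this assay the expected value is -0.2, with a range of -0.6 to 0.15. This estimate means a step of a number 0.40 log units lower from compound 1 to compound 3 (beyond the scatter), expected to be downward and modest.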

Compound 3, partition coefficient: -0.76
For compound 3 the middle estimate is 0.56 log units above the measured one; the whole stated range lies above it.
By their numbers in this assay, from the lowest: compound 3; then compounds 1 and 2 (each within the scatter of the next).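

In this assay, among these compounds, hydrogen in place of methyl on a saturated chain carbon bound to an amide-type nitrogen and a saturated chain carbon gives a number 0.96 log units lower from compound 1 to compound 3 (beyond the scatter), the first step that can be read at a single place. Among the compounds shown here, the two earlier compounds offered no such pair and could not be told apart on this read-out, whereas this pair shows that this position can move the number past the scatter, and downward, with the loss of just one carbon and no change in ring count, hydrogen-bond donors, hydrogen-bond acceptors or net charge. No measurement at hand accounts for the size of this step.

From the compounds shown here alone, one pair gives one step in one direction, so it remains open whether a longer chain, such as propyl or tert-butyl, at this place would move the number upward by a similar amount or by a different one. Going by these compounds, it also remains open how a hydroxyl group or an amine at this place would stand against methyl, and whether the same replacement would give a step of this size on another core.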